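Swapping the aryl ketone group in a chalcone-pyrazole series

The compounds below may be only part of what the source reports. "The series", "measured", "known", "first", "only" and "open" are said of these compounds alone.

Measured compounds:
compound 1, `COc1cc(-c2cc(/C=C/C(=O)c3ccc(Cl)c(Cl)c3)[nH]n2)cc(OC)c1OC`: -70%
compound 2, `COc1ccc(-c2cc(/C=C/C(=O)c3ccc(N)cc3)[nH]n2)cc1OC`: -99%
compound 3, `COc1ccc(C(=O)/C=C/c2cc(-c3cc(OC)c(OC)c(OC)c3)n[nH]2)cc1`: -41%

Of the compounds shown here, three sharing a pyrazole-linked enone core have been tested in a functional assay on SK-OV-3 cells (Homo sapiens) for cytotoxicity, read by sulforhodamine B assay, with a stated time of 48 h, tested at 100 uM; on this read-out higher numbers stand for a weaker effect at the one concentration tested and lower numbers for a stronger effect. Compound 1 `COc1cc(-c2cc(/C=C/C(=O)c3ccc(Cl)c(Cl)c3)[nH]n2)cc(OC)c1OC` gives -70%, compound 2 `COc1ccc(-c2cc(/C=C/C(=O)c3ccc(N)cc3)[nH]n2)cc1OC` gives -99%, and compound 3 `COc1ccc(C(=O)/C=C/c2cc(-c3cc(OC)c(OC)c(OC)c3)n[nH]2)cc1` gives -41%. Compound 3 therefore stands highest of the three numbers, beyond the scatter from both others, with compound 1 the nearest to it and compound 2 the furthest.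

Compound 4 `COc1cc(-c2cc(/C=C/C(=O)c3ccc(F)c(F)c3)[nH]n2)cc(OC)c1OC` is yet to be measured. It differs from compound 3 by 3,4-difluorophenyl in place of 4-methoxyphenyl on a carbonyl carbon.

For the measured compounds named here, one measured step bears directly on this change: a number 29 percentage points higher from compound 1 to compound 3 (beyond the scatter). That step put a halogenated ring in place of a methoxy-bearing ring on the same carbonyl carbon and moved the read-out upward by a modest amount. Going by the values given here, the change from compound 3 to compound 4 runs the other way, restoring a dihalogenated ring, so a downward step of comparable size is expected, though no difluoro analogue has been measured to confirm it.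

Compound 4 is therefore expected to show a number 24 percentage points lower from compound 3 to compound 4 (beyond the scatter), giving an estimated value of -65% with a range from -90% to -40%.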

Compound 4, a percentage reported as activity, at one concentration (the size of the read-out at that concentration, not a potency): -5%
Estimate against measurement, compound 4: 60 percentage points below, outside the stated range (above it).
By their numbers in this assay, from the lowest: compound 2; then compound 1; then compound 3; then compound 4.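

In this assay, the ring on the carbonyl carbon turns out to be a sensitive point in this series, and the earlier halogen-for-methoxy comparison did not capture how it behaves: 3,4-difluorophenyl in place of 4-methoxyphenyl gives a number 36 percentage points higher from compound 3 to compound 4 (beyond the scatter), which is the same direction as the earlier step, a number 29 percentage points higher from compound 1 to compound 3 (beyond the scatter), rather than its reverse. Exchanging one dihalogenated ring for the other gives a number 65 percentage points higher from compound 1 to compound 4 (beyond the scatter), so with the rest of the molecule held constant, 3,4-dichlorophenyl and 3,4-difluorophenyl fall on opposite sides of 4-methoxyphenyl, and at this position the two cannot be treated as one kind of ring. No measurement at hand bears on what lies behind this order.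

The three compounds that differ only on this ring leave open whether the order would extend to a ring with a single fluorine, a single chlorine or a trifluoromethyl group. Compound 2 differs from them in more than one place, so the part played by its 4-aminophenyl ring on the carbonyl carbon remains unseparated from that of its other ring.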